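A few compounds are considered here, and "the series" means these few. Any claim that something is new, unique, unknown or untested is made for them only; others in the source may bear on it.

Measured so far in a functional assay on KMS-11 cells (Homo sapiens) for antiproliferative activity, read by CellTiter-Glo, with a stated time of 72 h (on this read-out higher numbers stand for weaker inhibition and lower numbers for stronger inhibition), are three compounds:
Compound 1 `COc1ccc(C(=O)N(Cc2ccncc2)Cc2cccc(OCCc3cccc(C(F)(F)F)c3)c2)cc1` gives 8900 nM in this series
Compound 2 `COc1ccc(C(=O)N(Cc2ccncc2)Cc2cccc(OCC3CCOCC3)c2)cc1` gives 17700 nM in this series
Compound 3 `COc1ccc(C(=O)N(Cc2ccncc2)Cc2cccc(OCc3ccc(C(F)(F)F)cc3)c2)cc1` gives 14300 nM in this series

Compound 3, at 14300 nM on this read-out, stands within the scatter of both other compounds, so the three numbers set no order among them. Compound 4 `COc1ccc(C(=O)N(Cc2ccncc2)Cc2cccc(OCc3cccc(OC)c3)c2)cc1` is still unmeasured. It differs from compound 3 by 3-methoxyphenyl in place of 4-(trifluoromethyl)phenyl on a saturated chain carbon bound to an oxygen on an aromatic ring with 3-methoxyphenyl in place of 4-(trifluoromethyl)phenyl on a saturated chain carbon bound to an oxygen on an aromatic ring.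

All three measured steps change the group at this same place. The steps of a 2.0-fold higher number from compound 1 to compound 2 (0.30 log units; within the scatter) and a 1.6-fold higher number from compound 1 to compound 3 (0.21 log units; within the scatter) and a 1.2-fold lower number from compound 2 to compound 3 (0.09 log units; within the scatter) all lie within the scatter. Within the data shown here, none of the measured compounds carries 3-methoxyphenyl, so this evidence is indirect. On these steps, no change beyond the scatter is expected in this assay in either direction. The expected step is a 1.1-fold lower number from compound 3 to compound 4 (0.04 log units; within the scatter) and would lie within the scatter. For compound 4 the estimated value is 13000 nM with an expected range from 6500 nM to 26000 nM in this assay.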

Compound 4, half-maximal inhibitory concentration: 16900 nM
Estimate against measurement, compound 4: 1.3-fold (0.11 log units) below; low and high end bracket the measured number.
By their numbers in this assay, from the lowest: compounds 1, 3, 4 and 2 (each within the scatter of the next).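

In this assay, 3-methoxyphenyl in place of 4-(trifluoromethyl)phenyl gives a 1.2-fold higher number from compound 3 to compound 4 (0.07 log units; within the scatter) and so brings no change beyond the scatter, now with a methoxy-bearing aromatic group at this place. Set against the other two groups, the result is a 1.0-fold lower number from compound 2 to compound 4 (0.02 log units; within the scatter) and a 1.9-fold higher number from compound 1 to compound 4 (0.28 log units; within the scatter), both also within the scatter, so none of the four groups at this place separates from the others on this read-out. Nothing beyond these numbers bears on the result.

On these data alone, whether an amine or a carboxylic acid at this place would give a step beyond the scatter remains open. The compounds shown also leave open whether changes elsewhere on the shared core would do so, since all four differ only at this one place.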